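The source may hold more compounds than are shown below. What is called first, only, known or untested is meant among the compounds shown, and "the series" means these compounds.

Compound 1 `Cc1ccccc1C[C@H]1COC(=O)[C@@H]1Cc1ccc(Cl)c(Cl)c1`: 22000 nM in a functional assay on HL-60 cells (Homo sapiens) for cytotoxicity, read by WST assay, with a stated time of 48 h; on this read-out lower numbers stand for an effect already at smaller amounts and higher numbers for an effect only at larger amounts of compound; compound 2 `O=C1OC[C@H](Cc2ccccc2F)[C@H]1Cc1ccc(Cl)c(Cl)c1`: 28000 nM in this assay; compound 3 `Cc1ccccc1C[C@H]1COC[C@@H]1Cc1ccc(Cl)c(Cl)c1`: 21000 nM in this assay.

Compound 1 and compound 2 differ in one place, (fluoro in place of methyl on an aromatic carbon), and this change gave a 1.3-fold higher number from compound 1 to compound 2 (0.10 log units; within the scatter). Compound 3 shares with compound 1 the 2-methylphenyl group and the dichlorophenyl group, but the difference between the two cores is not broken down here; the numbers of compound 1 and compound 3 lie within the scatter of each other. Compound 4 `Fc1ccccc1C[C@H]1COC[C@@H]1Cc1ccc(Cl)c(Cl)c1` is not yet measured. It arises from compound 3 by the same change, (fluoro in place of methyl on an aromatic carbon), at the same place, on an aromatic carbon of a six-membered aromatic ring of carbon only, ortho to a large group. Because the earlier step was a 1.3-fold higher number from compound 1 to compound 2 (0.10 log units; within the scatter), the step from compound 3 to compound 4 is expected to be similar, a 1.3-fold higher number from compound 3 to compound 4 (0.11 log units; within the scatter). Compound 4 is therefore estimated at 27000 nM in this assay.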

Compound 4, half-maximal effective concentration: 51000 nM
Estimate against measurement, compound 4: 1.9-fold (0.28 log units) below; measured number inside the range.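

Replacing methyl with fluoro on the core of compound 3 gave a 2.4-fold higher number from compound 3 to compound 4 (0.39 log units; beyond the scatter) in this assay. Set beside the same change on the core of compound 1, the two steps do not differ by more than the scatter: the same change on two cores in this assay, a 1.3-fold higher number (0.10 log units; within the scatter) from compound 1 to compound 2 and a 2.4-fold higher number (0.39 log units; beyond the scatter) from compound 3 to compound 4, 1.9-fold (0.28 log units) apart, within the scatter of two such steps. This shows that, for these two cores, the step measured on one was an acceptable guide to the step on the other, but it rests on just two pairs, only one of which lies beyond the scatter on its own, and it does not show that the change would behave alike on any further core.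

The compounds shown leave open what other groups at this place, such as a methoxy or an amine, would do to the number.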